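Swapping Methyl for Bromo on Two Related Cores

The compounds below may be only part of what the source reports. "The series", "measured", "known", "first", "only" and "open" are said of these compounds alone.

Compound 1 `COC(=O)[C@@]1(C)CCC=C2[C@@H]1CC[C@@H](C)[C@]2(C)Cc1c[nH]c2ccc(C)cc12` and compound 2 `COC(=O)[C@@]1(C)CCC=C2[C@@H]1CC[C@@H](C)[C@]2(C)Cc1c[nH]c2ccc(Br)cc12` differ in a single place: bromo in place of methyl on an aromatic carbon. In a functional assay on SW1573 cells (Homo sapiens) for inhibition, read by sulforhodamine B assay, with a stated time of 48 h (a higher number here means a weaker inhibitor of growth, a lower number a stronger inhibitor of growth), compound 1 gives 15000 nM, and compound 2 gives 12000 nM, which amounts to a 1.3-fold lower number from compound 1 to compound 2 (0.10 log units; within the scatter). Compound 3 `COC(=O)[C@@]1(C)CC[C@@H]2C3=C1CC[C@@H](C)[C@]3(C)C[C@@H]1c3cccc(C)c3N[C@H]21` is built from the same atoms as compound 1, joined differently; the difference between the two cores is not broken down here. In this assay compound 3 gives 31000 nM, the highest of the three numbers and beyond the scatter from both others. Compound 4 `COC(=O)[C@@]1(C)CC[C@@H]2C3=C1CC[C@@H](C)[C@]3(C)C[C@@H]1c3cccc(Br)c3N[C@H]21` stands to compound 3 as compound 2 stands to compound 1, by the same kind of change: bromo in place of methyl on an aromatic carbon. The surroundings differ, though: in compound 1 the ring carrying the change is part of a fused system of two rings, meta and para to a fused ring, while in compound 3 it is part of a fused system of five rings, ortho and meta to a fused ring. Because the earlier step of a 1.3-fold lower number from compound 1 to compound 2 (0.10 log units; within the scatter) barely moved the number, compound 4 is expected to sit close to compound 3, with an estimated step of a 1.2-fold lower number from compound 3 to compound 4 (0.09 log units; within the scatter). The estimate for compound 4 in this assay is 25000 nM, expected to fall between 10000 nM and 60000 nM.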

Compound 4, concentration for 50% growth inhibition: 44000 nM
For compound 4 the middle estimate is 1.8-fold (0.25 log units) below the measured one; measured number inside the range.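

In this assay, putting bromo in place of methyl on the core of compound 3 gives a 1.4-fold higher number from compound 3 to compound 4 (0.15 log units; within the scatter), so on this core the swap produces no change that can be told apart from ordinary measurement scatter. The same swap on the two cores gives steps that agree as closely as such measurements can show: the same change on two cores in this assay, a 1.3-fold lower number (0.10 log units; within the scatter) from compound 1 to compound 2 and a 1.4-fold higher number (0.15 log units; within the scatter) from compound 3 to compound 4, 1.8-fold (0.25 log units) apart, within the scatter of two such steps. This shows that the change carries over from one core to the other as a swap with no readable effect on growth inhibition, and the printed directions of the two steps carry no meaning; it does not show how the swap would behave on a third core, and two pairs are too few to call it a rule for the series.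

On these data alone, all four compounds carry methyl or bromo on this aromatic carbon, so it remains open whether a different group there, such as an amine, a carboxylic acid or a longer chain, would move the number on either core. Also open, as far as these compounds go, is whether the swap would look the same in other cell lines.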